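A few compounds are considered here, and "the series" means these few. Any claim that something is new, unique, unknown or untested is made for them only; others in the source may bear on it.

In a functional assay on A2780 cells (Homo sapiens) for antiproliferative activity, read by MTT assay, with a stated time of 48 h (on this read-out higher numbers stand for weaker inhibition and lower numbers for stronger inhibition), compound 1 `COc1ccc(-c2cc3c(cn2)[nH]c(=O)n3-c2cc(OC)c(OC)c(OC)c2)cc1F` gives 730 nM, compound 2 `CCOc1ccc(-c2cc3c(cn2)[nH]c(=O)n3-c2cc(OC)c(OC)c(OC)c2)cc1` gives 2980 nM and compound 3 `COc1ccc(-c2cc3c([nH]c(=O)n3-c3cc(OC)c(OC)c(OC)c3)c(C(N)=O)n2)cc1F` gives 410 nM. Compound 3 thus stands with compound 1 at the low end of these numbers, well clear of compound 2. Carbamoyl in place of hydrogen accounts for a 1.8-fold lower number from compound 1 to compound 3 (0.25 log units; within the scatter). Compound 4 `CCOc1ccc(-c2cc3c([nH]c(=O)n3-c3cc(OC)c(OC)c(OC)c3)c(C(N)=O)n2)cc1` differs from compound 3 by 4-ethoxyphenyl in place of 3-fluoro-4-methoxyphenyl on an aromatic carbon: 4-ethoxyphenyl in place of 3-fluoro-4-methoxyphenyl, on an aromatic carbon next to the ring nitrogen. For the measured compounds named here, the same exchange, made without the carbamoyl group, gave a 4.1-fold higher number from compound 1 to compound 2 (0.61 log units; beyond the scatter), and this single pair is the only direct guide. A similar rise is therefore expected in this assay, amounting to an expected 3.7-fold higher number from compound 3 to compound 4 (0.56 log units; beyond the scatter). Compound 4 is estimated at 1500 nM, with an expected range of 600 nM to 3800 nM.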

Compound 4, half-maximal inhibitory concentration: 4600 nM
Estimate against measurement, compound 4: 3.1-fold (0.49 log units) below; measured number above the stated range.
By their numbers in this assay, from the lowest: compounds 3 and 1 (each within the scatter of the next); then compounds 2 and 4 (each within the scatter of the next).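

With the carbamoyl group present, 4-ethoxyphenyl in place of 3-fluoro-4-methoxyphenyl brings an 11-fold higher number from compound 3 to compound 4 (1.05 log units; beyond the scatter), so this exchange does not have one size across the two cores: the same change on two cores in this assay, a 4.1-fold higher number (0.61 log units; beyond the scatter) from compound 1 to compound 2 and an 11-fold higher number (1.05 log units; beyond the scatter) from compound 3 to compound 4, 2.7-fold (0.44 log units) apart, beyond the scatter of two such steps. Carbamoyl in place of hydrogen, with 4-ethoxyphenyl in place, gives a 1.5-fold higher number from compound 2 to compound 4 (0.19 log units; within the scatter), and the two carbamoyl steps also differ: the same change on two cores in this assay, a 1.8-fold lower number (0.25 log units; within the scatter) from compound 1 to compound 3 and a 1.5-fold higher number (0.19 log units; within the scatter) from compound 2 to compound 4, 2.7-fold (0.44 log units) apart, beyond the scatter of two such steps.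

The compounds shown leave open how much of the exchange belongs to the fluorine and how much to the ethoxy group, a question that plain 4-methoxyphenyl would address. From the compounds shown here alone, whether an amine or a carboxylic acid in place of the carbamoyl group would behave alike also stays open.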